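Acylation of the guanidine on the acyclic chain

The source may report more compounds than this note shows. Statements on the series, on what has been measured and on what is new or still open speak of the compounds shown alone.

The series is followed in a functional assay on A549 cells (Homo sapiens) for inhibition, read by MTT assay, with a stated time of 72 h; a lower number here means a stronger inhibitor of growth, a higher number a weaker inhibitor of growth. Compound 1 `CC(C)=CCC/C(C)=C/CC/C(C)=C/C(=O)NC(=N)N` gives 13700 nM, the lowest of the two numbers in hand. Among the measured compounds shown here, compound 3 `C=C1CCCC(C)(C)[C@@H]1CC/C(C)=C/C(=O)NC(=N)NC(=O)C=C(C)C` gives 29400 nM, a gap from compound 1 that lies beyond the scatter; the two differ in more than one place, so no single step is drawn between them. Compound 2 `CC(C)=CC(=O)NC(=N)N` reaches only a limit of the assay, > 100000 nM. That limit is the limit of > 100000 nM in this assay, at which 1 of the 3 values shown sits.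

Compound 4 `CC(C)=CCC/C(C)=C/CC/C(C)=C/C(=O)NC(=N)NC(=O)C=C(C)C` keeps the chain of compound 1 and differs from it in one place: (2-methylprop-1-en-1-yl)carbonyl in place of hydrogen on an amine nitrogen. Compound 3 already carries the same (2-methylprop-1-en-1-yl)carbonyl group on its guanidine and stands at the higher number of the two measured, but on a different chain, so it gives only a loose pointer. The step of a 1.5-fold higher number from compound 1 to compound 4 (0.16 log units; within the scatter) is expected to be small, toward a weaker inhibitor of growth if anything. Compound 4 is accordingly estimated at 20000 nM, within 7000 nM to 60000 nM.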

Compound 4, concentration for 50% growth inhibition: 23400 nM
Estimate against measurement, compound 4: 1.2-fold (0.07 log units) below, and the stated range covers the measured number.
By their numbers in this assay, from the lowest: compounds 1, 4 and 3 (each within the scatter of the next, the first and the last beyond it). At a limit, above all of these: compound 2.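

On the acyclic chain, (2-methylprop-1-en-1-yl)carbonyl in place of hydrogen on the amine nitrogen gives a 1.7-fold higher number from compound 1 to compound 4 (0.23 log units; within the scatter) in this assay. Among the compounds shown here, this is the first reading of this group at this position with the chain held constant, and it separates the effect of the change from any difference between chains; the free guanidine and its acylated form cannot be told apart in this assay. Nothing measured in the set bears on the reason for this result.

Still open, going by these compounds, is whether a smaller or larger acyl group on the same nitrogen, such as acetyl or benzoyl, would also stay within the scatter of the free guanidine. On these data alone, it is also open whether a longer chain or a carboxylic acid at the chain end would shift these numbers.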